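Aryl urea swap: compound 2 to compound 3

A few compounds are considered here, and "the series" means these few. Any claim that something is new, unique, unknown or untested is made for them only; others in the source may bear on it.

Measured in a functional assay on MIA PaCa-2 cells (Homo sapiens) for inhibition, read by MTT assay, with a stated time of 72 h; on this read-out lower numbers stand for stronger inhibition and higher numbers for weaker inhibition
- compound 1 (`COc1cc(NC(C)CCCNC(=O)Nc2ccc(F)cc2)c2ncccc2c1`) 21000 nM
- compound 2 (`COc1cc(NC(C)CCCNC(=O)Nc2cccc(C(F)(F)F)c2)c2ncccc2c1`) 17000 nM

Compound 2 cannot be separated from compound 1 on these numbers. Compound 3 (`COc1cc(NC(C)CCCNC(=O)Nc2ccc(Cl)cc2)c2ncccc2c1`) carries 4-chlorophenyl in place of 3-(trifluoromethyl)phenyl on an amide-type nitrogen. Among the compounds with values here, the only measured step at this place is a 1.2-fold lower number from compound 1 to compound 2 (0.09 log units; within the scatter) and it gives no ground for expecting a step beyond the scatter in this assay here. The estimated step is a 1.1-fold higher number from compound 2 to compound 3 (0.05 log units; within the scatter) and no real change is expected. Compound 3 is expected at 19000 nM (estimated range 10000 nM to 35000 nM).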

Compound 3, half-maximal inhibitory concentration: 22000 nM
Compound 3: middle estimate off by 1.2-fold (0.06 log units), on the low side; measured number inside the range.
By their numbers in this assay, from the lowest: compounds 2, 1 and 3 (each within the scatter of the next).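

In this assay a third aryl group on the amide-type nitrogen gives no separation: a 1.3-fold higher number from compound 2 to compound 3 (0.11 log units; within the scatter), and a 1.0-fold higher number from compound 1 to compound 3 (0.02 log units; within the scatter). The second step adds a clean halogen swap, chloro in place of fluoro on an aromatic carbon, and it also stays within the scatter. No evidence at hand bears on this flat result.

Still open, on these data alone, is whether an amine or a carboxylic acid on the aryl ring would move the number beyond the scatter. A longer chain in place of the shared one is equally untested by these compounds.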